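Removing the N-acyl group from the tetrahydroquinoline core

The source may hold more compounds than are shown below. What is called first, only, known or untested is meant among the compounds shown, and "the series" means these compounds.

In a functional assay on ACHN cells (Homo sapiens) for cytotoxicity, read by sulforhodamine B assay, with a stated time of 72 h (a lower number here means a stronger inhibitor of growth, a higher number a weaker inhibitor of growth), compound 1 `O=C(Nc1cc(C(F)(F)F)cc(C(F)(F)F)c1)C1CCc2ccccc2N1C(=O)c1cccc(Cl)c1` gives 813 nM. Its companion compound 2 `O=C(Nc1ccccc1C(F)(F)F)C1CCc2ccccc2N1C(=O)c1ccc(Cl)cc1` gives 824 nM in this assay, and the two numbers lie within the scatter of each other, so neither compound can be set apart from the other on these data. Both carry an acylated ring nitrogen on the shared core, with a chlorophenyl carbonyl in each case.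

The unmeasured compound 3 `O=C(Nc1cc(C(F)(F)F)cc(C(F)(F)F)c1)C1CCc2ccccc2N1` strips this group away. Relative to compound 1 the change is hydrogen in place of (3-chlorophenyl)carbonyl on a nitrogen on an aromatic ring in a ring. Among the compounds with values here, no pair of measured compounds shows a step of this kind, so the size of the step has to be judged from the change alone.

The account expects that losing the (3-chlorophenyl)carbonyl will weaken compound 3 in this assay, since that group makes up a large share of what compound 1 brings to its value of 813 nM. Compound 3 is estimated at 4500 nM, with a range from 1500 nM to 15000 nM. This estimate corresponds to a step of a 5.5-fold higher number from compound 1 to compound 3 (0.74 log units; beyond the scatter), beyond the scatter.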

Compound 3, concentration for 50% growth inhibition: 8190 nM
The estimate for compound 3 lay 1.8-fold (0.26 log units) below the measured number, and the stated range covers the measured number.
By their numbers in this assay, from the lowest: compounds 1 and 2 (each within the scatter of the next); then compound 3.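

In this assay, replacing the (3-chlorophenyl)carbonyl with hydrogen on this ring nitrogen gives a 10-fold higher number from compound 1 to compound 3 (1.00 log units; beyond the scatter). Within the data shown here, this is the first step seen at this position, and it shows that the group contributes to the growth inhibition of compound 1 by an amount beyond the scatter, which the near-identical numbers of the two acylated compounds could not show. Even so, the loss is not total: compound 3, which keeps the shared core and the amide with its two trifluoromethyl groups, still gives a finite value of 8190 nM, so growth inhibition in this assay does not depend entirely on an acyl group at this nitrogen. Nothing available here explains the size of the step.

The compounds shown leave open whether the step follows the carbonyl, the chlorophenyl ring or the chlorine, as this single change removes all three at once. An acetyl group, a benzyl group or an unsubstituted benzoyl group on this nitrogen would begin to separate these parts, and would show how much of the step each one carries.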